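Replacing 4-hydroxypiperidin-1-yl: expectations for compound 4

This account rests on a few compounds, and the source may have more. Where it says the series, first, only, none or still open, it means among the compounds named here.

- compound 1 `N#CC1(NC(=O)[C@@H]2C[C@@H](S(=O)(=O)c3ccccc3)C[C@H]2C(=O)N2CCOCC2)CC1`: 12 nM
- compound 2 `CC1CCN(C(=O)[C@@H]2C[C@H](S(=O)(=O)c3ccccc3)C[C@H]2C(=O)NC2(C#N)CC2)CC1`: 2 nM
- compound 3 `N#CC1(NC(=O)[C@@H]2C[C@@H](S(=O)(=O)c3ccccc3)C[C@H]2C(=O)N2CCC(O)CC2)CC1`: 371 nM

In a functional assay on A20 cells (Mus musculus) for inhibition, with stated times of 1 h, 16 h and 24 h (on this read-out lower numbers stand for stronger inhibition and higher numbers for weaker inhibition), compound 3 has the highest number of the three, at 371 nM, and its gaps to both others lie beyond the scatter. Compound 4 `N#CC1(NC(=O)[C@@H]2C[C@@H](S(=O)(=O)c3ccccc3)C[C@H]2C(=O)Nc2ccc(F)cc2)CC1` keeps the shared core and differs from compound 3 in one group: (4-fluorophenyl)amino in place of 4-hydroxypiperidin-1-yl on a carbonyl carbon. In words, this is (4-fluorophenyl)amino in place of 4-hydroxypiperidin-1-yl on a carbonyl carbon.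

All three measured steps fall at this same carbonyl carbon. The change a 31-fold higher number from compound 1 to compound 3 (1.49 log units; beyond the scatter) was large, as was the change a 190-fold higher number from compound 2 to compound 3 (2.27 log units; beyond the scatter), while the change a 6.0-fold lower number from compound 1 to compound 2 (0.78 log units; beyond the scatter) was modest. Only compound 3 carries the hydroxy group, and compound 4 gives it up, so a large step to a lower number is expected in this assay. For the measured compounds named here, no measured compound has (4-fluorophenyl)amino at this carbonyl carbon, so the expectation stays loose and the range is wide.

The estimate corresponds to an expected 19-fold lower number from compound 3 to compound 4 (1.27 log units; beyond the scatter). The estimated value for compound 4 is 20 nM, with an expected range of 3 nM to 150 nM.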

Compound 4, half-maximal inhibitory concentration: 391 nM
Beside the measured number, compound 4's estimate is 20-fold (1.29 log units) below it; the whole stated range lies below it.
By their numbers in this assay, from the lowest: compound 2; then compound 1; then compounds 3 and 4 (each within the scatter of the next).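

In this assay the step from the saturated 4-hydroxypiperidin-1-yl to the aromatic (4-fluorophenyl)amino on this carbonyl carbon separates nothing, as a 1.1-fold higher number from compound 3 to compound 4 (0.02 log units; within the scatter) shows, so the high number of compound 3 cannot be pinned on the hydroxy group alone: compound 4 has no hydroxy and still sits with it. The two low numbers remain with the other groups, with a 33-fold higher number from compound 1 to compound 4 (1.51 log units; beyond the scatter) and a 200-fold higher number from compound 2 to compound 4 (2.29 log units; beyond the scatter) standing as large steps, so among these four compounds only morpholin-4-yl and 4-methylpiperidin-1-yl give low numbers at this place. The leaving and entering groups each count 1 hydrogen-bond donor, but that is a shared count and no more, and no measurement at hand accounts for compounds 3 and 4 falling together.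

Open, from the compounds shown here alone, is whether the amide hydrogen of compound 4 matters, which a methyl(4-fluorophenyl)amino group would test, and whether the aromatic ring does, which a cyclohexylamino group would test. Equally open, going by these compounds, is whether methoxy in place of hydroxy on the saturated ring carbon would bring the piperidine series back towards compound 2.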